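From dimethylamino to phenyl: estimating compound 4

The source may hold more compounds than are shown below. What is called first, only, known or untested is meant among the compounds shown, and "the series" means these compounds.

Values in a physicochemical assay for solubility, with a stated time of 24 h, at pH 6.8 (a higher number here means a more soluble compound, a lower number a less soluble compound), for the measured compounds
- Compound 1 `O=C(Nc1cc2cccccc-2c1)c1cccnc1` gives 2 ug/mL as a measured number
- Compound 2 `COC(=O)c1ccc2ccc(C(=O)N(C)C)c-2cc1` gives > 64 ug/mL as a limit
- Compound 3 `CN(C)C(=O)c1cccc2ccccc12` gives > 43 ug/mL as a limit

Going by these compounds, compound 2 stands at > 64 ug/mL in this assay as a limit and not a number, so its exact place on the scale is unknown. Compound 4 `COC(=O)c1ccc2ccc(C(=O)c3ccccc3)c-2cc1` has not yet been measured. The change from compound 2 is (phenyl in place of dimethylamino on a carbonyl carbon), which in words is phenyl in place of dimethylamino on a carbonyl carbon.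

Within the data shown here, no two measured compounds differ in just one place, so the size of this step can only be judged loosely. Among the measured compounds shown here, compound 1, the only measured compound without dimethylamino, gives 2 ug/mL as a real number. Compound 3 carries dimethylamino and gives > 43 ug/mL as a limit. For the measured compounds named here, with only three compounds this is thin support, but it points one way. The reading for compound 4 in this assay is therefore expected to fall, by clearly more than the usual scatter. The estimated change is an at least 12-fold lower number from compound 2 to compound 4 (1.10 log units; beyond the scatter) as a drop towards the low end of the values seen so far. For compound 4 the estimate is 5 ug/mL with an expected range of (1 ug/mL to 20 ug/mL).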

Compound 4, solubility: < 1 ug/mL
Compound 4: no number, only a limit; the forecaster's own chance of this, stated with the estimate: 15%; middle value at least 5.0-fold (0.69 log units) away from the limit.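

In this assay, among these compounds, putting phenyl in place of dimethylamino on a carbonyl carbon is the first change in this set made at a single place, and it gives an at least 64-fold lower number from compound 2 to compound 4 (1.80 log units; beyond the scatter). The earlier compounds shown here differ from one another in more than one place, so they could only hint at this, whereas here the rest of the structure stays the same and the change at this carbonyl carbon alone moves the compound from the top of the values shown to the bottom. Compound 4 stands at a limit and not a number, so the true size of the step remains unknown: the limit of < 1 ug/mL in this assay, at which 1 of the 4 values shown sits.

Compound 2 is also a limit, which leaves the top end of the step just as unfixed: the limit of > 64 ug/mL in this assay, at which 1 of the 4 values shown sits. The compounds shown also cannot separate the loss of the nitrogen from the arrival of the aromatic ring, and a piperidine or a cyclohexyl group on the same carbonyl carbon is the kind of neighbouring case that could pull those two apart.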